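Trading a Hydroxy for Hydrogen on a Propyl Chain

A few compounds are considered here, and "the series" means these few. Any claim that something is new, unique, unknown or untested is made for them only; others in the source may bear on it.

Within the data shown here, compound 1 `Cc1cc(OCCCO)cc(C)c1-c1cccc(COc2ccc(OCC(=O)O)c(F)c2)c1` is the only compound here with a number to its name: in a physicochemical assay for lipophilicity, using the shake flask method, in phosphate buffer, measured as octanol-water partition, with a stated time of 24 h, at pH 7.4, tested at 100 uM (a lower number here means a more polar compound, a higher number a more lipophilic compound), compound 1 gives 2.73. Compound 2 `CC(=O)N(CC(=O)O)c1ccc(OCc2cccc(-c3c(C)cc(OCCCS(C)(=O)=O)cc3C)c2)cc1C` has no result in this assay; for compound 2 the entry reads "not determined" (no result reported). Compound 3 `CCCOc1cc(C)c(-c2cccc(COc3ccc(OCC(=O)O)c(F)c3)c2)c(C)c1` is not yet measured, and it differs from compound 1 in one place (hydrogen in place of hydroxy on a saturated chain carbon, three bonds along the chain from an oxygen on an aromatic ring). Among the measured compounds shown here, no step between measured compounds is available, so the expectation rests on this change alone. The step expected a number 1.17 log units higher from compound 1 to compound 3 (beyond the scatter) is a rise clearly beyond the usual scatter. Compound 3 is estimated at 3.9, with a range from 3.3 to 4.5.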

Compound 3, distribution coefficient: 3.64
Beside the measured number, compound 3's estimate is 0.26 log units above it; the range from low to high includes it.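

Going from 3-hydroxypropyl to propyl gives a number 0.91 log units higher from compound 1 to compound 3 (beyond the scatter) in this assay, so this single change on the chain registers clearly in the read-out. Among these compounds, this is the first measured step at this position; until now there was only one number, with nothing to compare it to. Nothing measured here explains the size of this step.

As far as these compounds go, only hydroxy and hydrogen are compared in this place, so the effect of an amine or a methoxy group there remains open. So does the effect of a longer chain, such as butyl in place of propyl.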